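A few compounds are considered here, and "the series" means these few. Any claim that something is new, unique, unknown or untested is made for them only; others in the source may bear on it.

Notes on the series. Compound 1 `O=C(c1ccccc1F)N1CC[C@H]1c1nc(-c2cccc(F)c2)no1` in an assay on HEK293 cells for positive allosteric modulation of metabotropic glutamate receptor 5 (Homo sapiens), read by FLIPR (on this read-out higher numbers stand for an effect only at larger amounts of compound and lower numbers for an effect already at smaller amounts), gives > 10000 nM, which is a limit of the assay and not a number (the limit of > 10000 nM in this assay, at which 1 of the 3 values shown sits). Among the measured compounds shown here, compound 2 `O=C(C1CCCCC1)N1CC(c2nc(-c3cccc(F)c3)no2)C1` carries cyclohexyl on the carbonyl carbon, and in this assay compound 2 gives 1000 nM, the highest of the two numbers known. Compound 3 `O=C(C1CCC(C(F)(F)F)CC1)N1CC(c2nc(-c3cccc(F)c3)no2)C1` carries trifluoromethyl in place of hydrogen on a saturated ring carbon; in this assay compound 3 gives 680 nM, and the step of a 1.5-fold lower number from compound 2 to compound 3 (0.17 log units; within the scatter) is within the scatter. Compound 4 `O=C([C@H]1CC2CCC1C2)N1CC(c2nc(-c3cccc(F)c3)no2)C1` differs from compound 2 by a group of 7 heavy atoms (7 carbon; 2 five-membered non-aromatic rings of carbon only) in place of a group of 6 heavy atoms (6 carbon; one six-membered non-aromatic ring of carbon only), on a carbonyl carbon. For the measured compounds named here, the only measured step touching the saturated ring on the carbonyl carbon was within the scatter, so no shift beyond the scatter is expected here. Compound 4 is therefore estimated at 800 nM in this assay, between 300 nM and 2500 nM, an expected step of a 1.3-fold lower number from compound 2 to compound 4 (0.10 log units; within the scatter).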

Compound 4, half-maximal effective concentration: 72 nM
Beside the measured number, compound 4's estimate is 11-fold (1.05 log units) above it; the measured number lies below the stated range.
By their numbers in this assay, from the lowest: compound 4; then compounds 3 and 2 (each within the scatter of the next). At a limit, above all of these: compound 1.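

Unlike the earlier change on this ring, the step at the carbonyl carbon is large: swapping cyclohexyl for the group with 2 five-membered non-aromatic rings of carbon only gives a 14-fold lower number from compound 2 to compound 4 (1.14 log units; beyond the scatter). The position therefore responds to the carbon-only group itself, with no added hydrogen-bond donor, acceptor or net charge. No measurement shown gives a cause for this step.

Open, as far as these compounds go, is how far the result depends on the defined stereocentre of compound 4. Also open, from the compounds shown here alone, is whether an amine or a hydroxyl on this saturated group would keep the effect.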